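Notes on replacing 5-nitrothiophen-3-yl with 4-iodophenyl

A few compounds are considered here, and "the series" means these few. Any claim that something is new, unique, unknown or untested is made for them only; others in the source may bear on it.

In a functional assay on DU-145 cells (Homo sapiens) for inhibition, read by trypan blue exclusion, with a stated time of 96 h (on this read-out lower numbers stand for stronger inhibition of growth and higher numbers for weaker inhibition of growth), compound 1 (`Cc1ccc(S/C(=C/c2ccc(Br)cc2)C(=O)c2ccc(Cl)cc2)cc1`) gives 25000 nM as the higher number. Compound 2 (`O=C(/C(=C\c1csc([N+](=O)[O-])c1)S(=O)(=O)c1ccc(Br)cc1)c1ccc(Br)cc1`) gives 1000 nM and stands lowest of the two numbers, a gap beyond the scatter. Compound 3 (`O=C(/C(=C\c1ccc(I)cc1)S(=O)(=O)c1ccc(Br)cc1)c1ccc(Br)cc1`) differs from compound 2 by one change (4-iodophenyl in place of 5-nitrothiophen-3-yl on a double-bonded chain carbon bound to a double-bonded chain carbon): 4-iodophenyl in place of 5-nitrothiophen-3-yl on a double-bonded chain carbon bound to a double-bonded chain carbon. Among the measured compounds shown here, no measured pair shows this change alone. In this assay a modest rise is expected, an estimated 2.5-fold higher number from compound 2 to compound 3 (0.40 log units; beyond the scatter) toward weaker inhibition of growth. Compound 3 is estimated at 2500 nM with an expected range from 600 nM to 10000 nM in this measurement.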

Compound 3, concentration for 50% growth inhibition: 1000 nM
Compound 3: the middle estimate sits 2.5-fold (0.40 log units) above what was measured; low and high end bracket the measured number.
By their numbers in this assay, from the lowest: compounds 2 and 3 (each within the scatter of the next); then compound 1.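

In this assay, the exchange of 5-nitrothiophen-3-yl for 4-iodophenyl on a double-bonded chain carbon bound to a double-bonded chain carbon gives no change at the digits printed from compound 2 to compound 3 (within the scatter). At this position, a five-membered aromatic ring with 1 hetero atom and a six-membered aromatic ring of carbon only are thus not told apart by this read-out. Nothing at hand bears on why the two groups read alike.

On these data alone, whether this tolerance extends to a ring carrying an amine or a carboxylic acid remains open. So does whether an unsubstituted phenyl at this position would read the same.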